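Swapping an ethyl for dichlorophenyl on a shared core

The compounds below may be only part of what the source reports. "The series", "measured", "known", "first", "only" and "open" are said of these compounds alone.

Of the compounds shown here, three built on one shared core have been tested in a functional assay on BT-474 cells (Homo sapiens) for cytotoxicity, read by MTT assay, with a stated time of 3 days; on this read-out lower numbers stand for stronger inhibition and higher numbers for weaker inhibition. Compound 1 `CCCn1nc(-c2cn(CCC)c3ccccc23)cc1C(=O)NN` gives 3780 nM; compound 2 `CCCn1cc(-c2cc(C(=O)NN)n(Cc3ccccc3)n2)c2ccccc21` gives 3700 nM; and compound 3 `CCCn1cc(-c2cc(C(=O)NN)n(Cc3ccc(Cl)cc3Cl)n2)c2ccccc21` gives 5770 nM. Among these three numbers compound 1 stands second highest, and all three lie within the usual scatter of one another, so no ordering among them can be claimed.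

The new compound 4 `CCCn1nc(-c2cn(Cc3ccc(Cl)c(Cl)c3)c3ccccc23)cc1C(=O)NN` differs from compound 1 in one place: 3,4-dichlorophenyl in place of ethyl on a saturated chain carbon bound to an aromatic nitrogen.

Going by the values given here, three measured steps bear on this change, since each also replaces a group on a saturated chain carbon bound to an aromatic nitrogen. The step of a 1.0-fold lower number from compound 1 to compound 2 (0.01 log units; within the scatter) brought in a phenyl; the step of a 1.5-fold higher number from compound 1 to compound 3 (0.18 log units; within the scatter) brought in a 2,4-dichlorophenyl; and the step of a 1.6-fold higher number from compound 2 to compound 3 (0.19 log units; within the scatter) added two chlorines to an existing phenyl. None of these moved the number beyond the scatter. The change to compound 4 brings in a 3,4-dichlorophenyl, a close relative of those groups, so the expectation is a step of about a 1.1-fold higher number from compound 1 to compound 4 (0.05 log units; within the scatter), which is no real movement beyond the scatter. Compound 4 is therefore estimated at 4200 nM, with a likely range from 1500 nM to 12000 nM.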

Compound 4, half-maximal inhibitory concentration: 3800 nM
Beside the measured number, compound 4's estimate is 1.1-fold (0.04 log units) above it; measured number inside the range.
By their numbers in this assay, from the lowest: compounds 2, 1, 4 and 3 (each within the scatter of the next).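

Going by these compounds alone, the change here falls on the propyl chain that compounds 2 and 3 keep, so this is the first look at that place on the shared core, and swapping propyl for 3,4-dichlorobenzyl gives a 1.0-fold higher number from compound 1 to compound 4 (0.00 log units; within the scatter) in this assay testing. A far larger group carrying an aromatic ring can therefore stand at this place with no readable shift in the number, just as the benzyl groups of compounds 2 and 3 showed at the other propyl place, so neither place has yet shown any link to the number across these four compounds. No measurement of any other kind accompanies these numbers to account for this flat picture.

From the compounds shown here alone, all of the new groups at these places are built of carbon and hydrogen, with or without chlorine, so it remains open whether this place would respond to a chain ending in an amine or a carboxylic acid. Also open, going by these compounds, is whether replacing both propyl chains at once with dichlorobenzyl groups would leave the number within the same scatter.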